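Ghrelin receptor antagonist series: methoxy for tert-butyl

The compounds below may be only part of what the source reports. "The series", "measured", "known", "first", "only" and "open" are said of these compounds alone.

Three compounds of the shared core have numbers in an in vitro functional assay on CHO-CREluc cells for antagonist activity at growth hormone secretagogue receptor type 1 (Homo sapiens), read by a luciferase reporter, with a stated time of 4 h; a higher number here means a weaker inhibitor, a lower number a stronger inhibitor. Compound 1 `CN1CCN(CC(=O)NC2(c3ccc(Cl)cc3)C(=O)Nc3cc(Cl)ccc32)CC1` gives 140 nM. Compound 3 `C=CCN1CCN(CC(=O)NC2(c3ccc(Cl)c(Cl)c3)C(=O)Nc3cc(Cl)cc(Cl)c32)CC1` gives 38 nM. Compound 2 `CN1CCN(CC(=O)NC2(c3ccc(C(C)(C)C)cc3)C(=O)Nc3cc(Cl)c(Cl)cc32)CC1` gives 1470 nM, the highest of the three, with compound 1 the nearest and compound 3 the furthest, both gaps beyond the scatter.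

Compound 4 `COc1ccc(C2(NC(=O)CN3CCN(C)CC3)C(=O)Nc3cc(Cl)c(Cl)cc32)cc1` is not yet measured. It differs from compound 2 in one place: methoxy in place of tert-butyl on an aromatic carbon. Among the compounds with values here, no measured pair shows this exact change, so the direction rests on compound 1, which carries a smaller group on the same ring and gives 140 nM, though its core differs as well.

Compound 4 is expected to give 500 nM, within 150 nM to 1600 nM, in this assay. The step of a 2.9-fold lower number from compound 2 to compound 4 (0.47 log units; beyond the scatter) is expected to be a modest fall, of uncertain size, because compound 1 stands at 140 nM.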

Compound 4, half-maximal inhibitory concentration: 700 nM
The estimate for compound 4 lay 1.4-fold (0.15 log units) below the measured number; the measured number falls inside the stated range.
By their numbers in this assay, from the lowest: compound 3; then compound 1; then compound 4; then compound 2.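

In this assay, within the data shown here, this is the first pair that isolates the group at this place on the shared core: methoxy in place of tert-butyl gives a 2.1-fold lower number from compound 2 to compound 4 (0.32 log units; beyond the scatter) on an aromatic carbon. The 4-(tert-butyl)phenyl to 4-methoxyphenyl change therefore has a modest effect here, though one beyond the scatter, and the number stays in the same general range. Open, going by these compounds, is whether a nitrile, a dimethylamino group or a hydroxyl at this place would move the number further, and whether the same change would behave alike on the core of compound 1. No available data explain the step.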